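Step from compound 2 to compound 4: hexyl for 4-chlorophenyl

The source may report more compounds than this note shows. Statements on the series, on what has been measured and on what is new or still open speak of the compounds shown alone.

The series shares one core and varies the group carried on the ether oxygen. Compound 1 `CCc1nncn1-c1ccc(OCc2c(F)cccc2F)cc1` gives 15.8 mg/kg in a functional assay on the whole organism (strain C57B/6) with Mus musculus as the target, in the maximal electroshock model; on this read-out higher numbers stand for an effect only at larger amounts of compound and lower numbers for an effect already at smaller amounts. Compound 2 `CCc1nncn1-c1ccc(OCc2ccc(Cl)cc2)cc1` gives 19.7 mg/kg in this assay, and compound 3 `CCc1nncn1-c1ccc(OCc2ccc(OC)cc2)cc1` gives 15.8 mg/kg in this assay. Compound 2 carries the largest of the three numbers, yet its separation from compound 1 and from compound 3 is within the scatter, so no order among the three is established. For the measured compounds named here, the one single-point step measured so far, a 1.2-fold lower number from compound 2 to compound 3 (0.10 log units; within the scatter), is a swap of one substituent for another on the aromatic ring and stays within the scatter.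

Compound 4 `CCCCCCCOc1ccc(-n2cnnc2CC)cc1` differs from compound 2 by hexyl in place of 4-chlorophenyl on a saturated chain carbon bound to an oxygen on an aromatic ring. Going by the values given here, no measured step exchanges an aromatic ring for a chain, so the only comparison available is indirect: the aryl-substituent swap from compound 2 to compound 3 moved nothing beyond the scatter. On that thin basis the step from compound 2 to compound 4 is expected to stay near a 1.1-fold higher number from compound 2 to compound 4 (0.05 log units; within the scatter), with a wide margin either way. Compound 4 is therefore estimated at 22 mg/kg in this assay, in a range from 9 mg/kg to 55 mg/kg.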

Compound 4, dose for half-maximal effect: 8.3 mg/kg
The estimate for compound 4 lay 2.7-fold (0.42 log units) above the measured number, outside the stated range (below it).
By their numbers in this assay, from the lowest: compounds 4, 1, 3 and 2 (each within the scatter of the next, the first and the last beyond it).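

For the compounds shown here, replacing the ring with a chain at this position moves the number further than anything seen so far: a 2.4-fold lower number from compound 2 to compound 4 (0.38 log units; beyond the scatter) is the first step beyond the scatter, whereas the swap on the ring, a 1.2-fold lower number from compound 2 to compound 3 (0.10 log units; within the scatter), is not. An aromatic ring on the saturated chain carbon bound to the ether oxygen is therefore not a condition for activity in this assay, since compound 4 has no ring there and still gives 8.3 mg/kg. The result rests on a single modest step, so it marks the position as open to change rather than defining a trend.

Still open, from the compounds shown here alone, is whether a shorter or longer chain would hold this value, and whether cyclohexyl would behave like hexyl or like 4-chlorophenyl. No supporting data account for the size of this step.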